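Benzyl in place of ethyl on a cyanoguanidine

The source may hold more compounds than are shown below. What is called first, only, known or untested is meant among the compounds shown, and "the series" means these compounds.

Of the compounds shown here, two have been measured in a physicochemical assay for lipophilicity, using the shake flask method, measured as octanol-water partition, at 23 degrees C; on this read-out lower numbers stand for lower lipophilicity and higher numbers for higher lipophilicity. Compound 1 `CN/C(=N\C#N)N(C)Cc1ccc(Cl)nc1` gives 0.78. Compound 2 `CCN/C(=N\C#N)N(C)Cc1ccc(Cl)nc1` gives 1.02, the higher of the two numbers, with compound 1 as its nearest neighbour; the step of a number 0.24 log units higher from compound 1 to compound 2 (within the scatter) stays within the scatter of repeated measurements. Compound 3 `CN(Cc1ccc(Cl)nc1)/C(=N/C#N)NCc1ccccc1` has not yet been measured. It differs from compound 2 by phenyl in place of methyl on a saturated chain carbon bound to an amine nitrogen. Within the data shown here, the only measured step that bears on this change is the one from compound 1 to compound 2, which added a single carbon at the same place and moved the number by a number 0.24 log units higher from compound 1 to compound 2 (within the scatter). The change to compound 3 adds six carbons in an aromatic ring at that position, so a markedly larger step upward is expected rather than one within the scatter. Compound 3 is therefore estimated at 2.6, with a range from 2 to 3.2. The estimated step of a number 1.58 log units higher from compound 2 to compound 3 (beyond the scatter) is expected to lie well beyond the scatter of this assay.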

Compound 3, partition coefficient: 1.32
Compound 3: the middle estimate sits 1.28 log units above what was measured; the whole stated range lies above it.
By their numbers in this assay, from the lowest: compounds 1, 2 and 3 (each within the scatter of the next, the first and the last beyond it).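

In this assay, the change from ethyl to benzyl comes out as a number 0.30 log units higher from compound 2 to compound 3 (within the scatter), so at this place on a saturated chain carbon bound to an amine nitrogen, the arrival of a six-membered aromatic ring leaves compound 3 and compound 2 not separated by this read-out. Only the larger exchange at the same place, phenyl in place of hydrogen, passes the scatter, at a number 0.54 log units higher from compound 1 to compound 3 (beyond the scatter), a step the earlier pair could not show, since it offered a single added carbon and nothing more. No measurement available here speaks to why the aromatic ring shifts the number so little at this place.

Still open, on these data alone, is whether a longer chain in place of ethyl would stay within the scatter of compound 2, and whether an amine or a carboxylic acid carried on the phenyl of compound 3 would move the number beyond it. All three compounds vary at this one place, so they say nothing about how the rest of the shared core responds to change in this read-out.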